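A few compounds are considered here, and "the series" means these few. Any claim that something is new, unique, unknown or untested is made for them only; others in the source may bear on it.

Compound 1 `CCOC(=O)NC/C=C\CN(C)C[C@H]1O[C@@H](n2c(C)nc3c(N)ncnc32)[C@H](O)[C@@H]1O`: > 1.5 h
Compound 2 `Cc1nc2c(N)ncnc2n1[C@@H]1O[C@H](CN(C/C=C\CN)C2CC2)[C@@H](O)[C@H]1O`: > 1.5 h
Compound 3 `CNc1ncnc2c1ncn2[C@@H]1O[C@H](CN(C)C/C=C\CN)[C@@H](O)[C@H]1O`: > 1.5 h

All three readings come from an ADME assay on microsomes from liver (Homo sapiens) for metabolic stability, read by LC-MS, using NADPH, tested at 1 uM (on this read-out lower numbers stand for a shorter-lived compound and higher numbers for a longer-lived compound), and each is a limit of the assay rather than a number. The series therefore shows only (the limit of > 1.5 h in this assay, at which 3 of the 3 values shown sit). Compound 3 stands at its limit of > 1.5 h, with no number to place it more exactly. Compound 4 `CCOc1ncnc2c1ncn2[C@@H]1O[C@H](CN(C)C/C=C\CN)[C@@H](O)[C@H]1O` carries ethoxy in place of methylamino on an aromatic carbon, next to the ring nitrogen: ethoxy in place of methylamino on an aromatic carbon. For the measured compounds named here, no two measured compounds differ in one place alone, so the series gives no direct guide to this change. The expected step in this assay is a number no higher from compound 3 to compound 4 (the limit leaves the size open), estimated to stay within the scatter, with no direction favoured. For compound 4 the estimated half-life is 1.5 h, with an expected range from 0.7 h to 3 h.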

Compound 4, half-life: > 1.5 h
Compound 4: no number, only a limit; the forecaster's own chance of this, stated with the estimate: 60%; the middle value lies on the limit itself.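

Compound 3 and compound 4 both stand at a limit of the assay, and no step between them can be read: the limit of > 1.5 h in this assay, at which 4 of the 4 values shown sit.

The compounds shown leave open the actual half-life of each, and whether ethoxy in place of methylamino on an aromatic carbon alters it at all.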